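Methyl on the piperazine ring and TRPV1 antagonism

A few compounds are considered here, and "the series" means these few. Any claim that something is new, unique, unknown or untested is made for them only; others in the source may bear on it.

Measured compounds:
compound 1 `CC(C)(C)c1ccc2[nH]c(N3CCN(c4ncccc4Cl)CC3)nc2c1`: 1690 nM
compound 2 `C[C@@H]1CN(c2ncccc2Cl)CCN1c1nc2ccc(C(C)(C)C)cc2[nH]1`: 104 nM

In a functional assay on HEK293 cells for antagonist activity at transient receptor potential cation channel subfamily V member 1 (Homo sapiens), read by FLIPR, at pH 5.5 (a higher number here means a weaker inhibitor, a lower number a stronger inhibitor), compound 1 gives 1690 nM, the higher of the two numbers in hand. Compound 2, which also carries a methyl on a carbon of the six-membered non-aromatic ring with two nitrogens, gives 104 nM, a difference that lies well beyond the scatter.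

Compound 3 `C[C@H]1CN(c2ncccc2Cl)CCN1c1nc2cc(C(C)(C)C)ccc2[nH]1` has not been measured. It differs from compound 1 as follows: methyl in place of hydrogen on a saturated ring carbon. For the measured compounds named here, since no measured pair shows this exact step, its size can only be estimated. Given that compound 2 with its own methyl on that ring gives 104 nM, the step is expected to lower the number, though the stereochemistry written for compound 3 leaves its size uncertain; the expected step is a 4.8-fold lower number from compound 1 to compound 3 (0.68 log units; beyond the scatter). Compound 3 is therefore estimated at 350 nM, within a range of 80 nM to 1500 nM.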

Compound 3, half-maximal inhibitory concentration: 3610 nM
For compound 3 the middle estimate is 10-fold (1.01 log units) below the measured one; measured number above the stated range.
By their numbers in this assay, from the lowest: compound 2; then compound 1; then compound 3.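

In this assay the methyl on a saturated ring carbon, next to the ring nitrogen, gives a 2.1-fold higher number from compound 1 to compound 3 (0.33 log units; beyond the scatter) and thus moves the number up, not down, by a modest step. For the compounds shown here, a methyl on this ring therefore does not by itself bring a number as low as the one compound 2 gives at 104 nM in the same assay, and no single-change step links compound 2 to compound 1 or compound 3. Nothing in hand explains why the methyl in compound 3 raises the number.

What sets compound 2 apart from compound 3 remains unresolved, including how much the stereochemistry written at the methyl-bearing carbon contributes. From the compounds shown here alone, it is also open whether an ethyl or a hydroxymethyl on this ring carbon would raise the number as the methyl of compound 3 does.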